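Thiophene for Furan on an Inactive Nucleoside Pair

The source may hold more compounds than are shown below. What is called first, only, known or untested is meant among the compounds shown, and "the series" means these compounds.

Of the compounds shown here, two have been tested in a functional assay on HCT-116 cells (Homo sapiens), read by MTT assay, with a stated time of 72 h (on this read-out lower numbers stand for stronger inhibition and higher numbers for weaker inhibition), and neither has given a number. Compound 1 `Cc1ncnc2c1c(-c1cccs1)cn2[C@@H]1O[C@H](CO)[C@@H](O)[C@H]1O` carries a methyl group and a thiophen-2-yl ring on the shared core; in this assay compound 1 returns only the limit of the assay, > 20000 nM. Compound 2 `CN(C)c1ncnc2c1c(-c1ccoc1)cn2[C@@H]1O[C@H](CO)[C@@H](O)[C@H]1O` bears a dimethylamino group together with a furan-3-yl ring; in this assay compound 2 likewise returns only a limit, > 20000 nM. So compound 2 stands where every measured value of the set stands, at the limit of > 20000 nM in this assay, at which 2 of the 2 values shown sit, and no step between measured compounds can be drawn from two limits.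

Compound 3 `CN(C)c1ncnc2c1c(-c1cccs1)cn2[C@@H]1O[C@H](CO)[C@@H](O)[C@H]1O` differs from compound 2 in one place: thiophen-2-yl in place of furan-3-yl on an aromatic carbon. The same thiophen-2-yl ring is present in compound 1, which also sits at the limit. The expectation for compound 3 is therefore no step beyond the scatter, with the change a number no higher from compound 2 to compound 3 (the limit leaves the size open) most likely leaving it at the limit. Compound 3 is estimated at 20000 nM, in the range 10000 nM to 40000 nM, with a strong chance that only a limit is again reported.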

Compound 3, half-maximal inhibitory concentration: > 20000 nM
Compound 3: a limit, no number (the forecaster's own chance of this, stated with the estimate: 75%); the middle value lies on the limit itself.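

In this assay compound 3 gives only a limit, > 20000 nM. Among the compounds shown here, no step from compound 1 or compound 2 to compound 3 can therefore be read, as all three compounds stand at a limit: the limit of > 20000 nM in this assay, at which 3 of the 3 values shown sit. The compounds shown leave open whether any group at these two places on the shared core would give a measurable number in this assay.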